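From 3-chlorobenzyl to 2-fluorobenzyl: what number to expect

The compounds below may be only part of what the source reports. "The series", "measured", "known", "first", "only" and "open" are said of these compounds alone.

Three related compounds have been tested in a functional assay on MCF7 cells (Homo sapiens) for cytotoxicity, read by MTT assay, with a stated time of 24 h; a higher number here means a weaker inhibitor, a lower number a stronger inhibitor. Compound 1 `Cc1ccc(/C=C2\CN(Cc3cn(Cc4ccc(F)cc4)nn3)C/C(=C\c3ccc(C)cc3)C2=O)cc1` gives 29000 nM. Compound 2 `Cc1ccc(/C=C2\CN(Cc3cn(Cc4cccc(Cl)c4)nn3)C/C(=C\c3ccc(C)cc3)C2=O)cc1` gives 10000 nM, the lower of the two actual numbers. Compound 3 `COc1ccc(/C=C2\CN(Cc3cn(Cc4ccc(F)cc4)nn3)C/C(=C\c3ccc(OC)cc3)C2=O)cc1` gives only a limit of the assay, > 100000 nM.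

Compound 4 `Cc1ccc(/C=C2\CN(Cc3cn(Cc4ccccc4F)nn3)C/C(=C\c3ccc(C)cc3)C2=O)cc1` has not yet been measured. It differs from compound 2 in one place: 2-fluorophenyl in place of 3-chlorophenyl on a saturated chain carbon bound to an aromatic nitrogen. In words, 2-fluorophenyl stands in place of 3-chlorophenyl on a saturated chain carbon bound to an aromatic nitrogen, so that 3-chlorobenzyl becomes 2-fluorobenzyl.

Going by the values given here, one measured step bears on this change: a 2.9-fold lower number from compound 1 to compound 2 (0.46 log units; beyond the scatter), with 3-chlorophenyl in place of 4-fluorophenyl at that same spot. The new change runs the opposite way, from the chlorinated group back to a fluorinated one, although the group is 2-fluorophenyl and not 4-fluorophenyl. A single modest step is thin evidence, so the forecast is loose. Resting on that step, a modest rise of the number in this assay is expected, a 2.2-fold higher number from compound 2 to compound 4 (0.34 log units; beyond the scatter). The estimate for compound 4 is 22000 nM, with an expected range from 8000 nM to 60000 nM.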

Compound 4, half-maximal inhibitory concentration: 28700 nM
For compound 4 the middle estimate is 1.3-fold (0.12 log units) below the measured one; the range from low to high includes it.
By their numbers in this assay, from the lowest: compound 2; then compounds 4 and 1 (each within the scatter of the next). At a limit, above all of these: compound 3.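

Putting 2-fluorophenyl in place of 3-chlorophenyl on the saturated chain carbon gives a 2.9-fold higher number from compound 2 to compound 4 (0.46 log units; beyond the scatter) and shows that a different fluorinated group at this spot does not keep the lower number of compound 2. Putting 2-fluorophenyl in place of 4-fluorophenyl gives a 1.0-fold lower number from compound 1 to compound 4 (0.00 log units; within the scatter) in this assay and shows that these two fluorinated compounds cannot be told apart, whichever of the two fluorophenyl groups they carry. Among compound 1, compound 2 and compound 4, which differ only at this spot, the 3-chlorophenyl group of compound 2 alone stands apart with a lower number, and none of the three goes against that reading.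

Still open, from the compounds shown here alone, is whether the lower number of compound 2 belongs to the chlorine itself or to where it sits on the ring, and how an unsubstituted benzyl group, a 3-bromobenzyl group or a 3-methoxybenzyl group would compare at this spot. Nothing measured among these compounds gives a reason for the gap between the chlorinated group and the two fluorinated ones.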